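Working notes: furan-2-yl in place of trifluoromethyl

A few compounds are considered here, and "the series" means these few. Any claim that something is new, unique, unknown or untested is made for them only; others in the source may bear on it.

- compound 1 `O=[N+]([O-])C1=CNc2nc(C(F)(F)F)nn2C1c1ccc(O)c(O)c1`: 1210000 nM
- compound 2 `O=[N+]([O-])C1=CNc2ncnn2C1O`: 123000 nM
- compound 3 `O=[N+]([O-])C1=NNc2nc(C(F)(F)F)nn2C1c1c(O)cc(O)cc1O`: 252000 nM

In an ADME assay on MDCK cells (Canis lupus familiaris) for cytotoxicity (on this read-out higher numbers stand for lower toxicity in this test and lower numbers for higher toxicity in this test), compound 1 stands highest of the three, and both others lie lower by more than the scatter. Compound 4 `O=[N+]([O-])C1=CNc2nc(-c3ccco3)nn2C1c1ccc(O)c(O)c1` carries furan-2-yl in place of trifluoromethyl on an aromatic carbon. Among the compounds with values here, no measured pair isolates this change, so the expectation is loose. With compound 1 at 1210000 nM, the top of the measured span, a moderate fall is expected rather than a rise. The expected change is a 2.4-fold lower number from compound 1 to compound 4 (0.38 log units; beyond the scatter). For compound 4 the estimated value is 500000 nM, with an expected range of 150000 nM to 1500000 nM.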

Compound 4, half-maximal cytotoxic concentration: > 1200000 nM
Compound 4 ended at the assay's limit (the forecaster's own chance of this, stated with the estimate: 10%); at least 2.4-fold (0.38 log units) between middle value and limit.
By their numbers in this assay, from the lowest: compound 2; then compound 3; then compound 1.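

In this assay, within the data shown here, compound 4 gives > 1200000 nM, which is a limit of the assay and not a number, so no step from compound 1 can be read. The compounds shown leave open how far furan-2-yl in place of trifluoromethyl on an aromatic carbon shifts this read-out, or whether it shifts it at all.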